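Amino to nitro on the weak methoxy compound

The compounds below may be only part of what the source reports. "The series", "measured", "known", "first", "only" and "open" are said of these compounds alone.

Measured in an ADME assay on CNE-2 cells (Homo sapiens) for cytotoxicity, read by MTT assay, with a stated time of 48 h; a higher number here means a weaker inhibitor, a lower number a stronger inhibitor:
- Compound 1 `COc1ccc(-c2cn(Cc3ccc(C(C)(C)C)cc3)nn2)c(N)c1`: > 20000 nM (a limit, not a number)
- Compound 2 `CC(C)(C)c1ccc(Cn2cc(-c3ccc(O)cc3N)nn2)cc1`: 1600 nM

Compound 1 is known only as a limit, and its place on the scale is the limit of > 20000 nM in this assay, at which 1 of the 2 values shown sits. The next structure, compound 3 `COc1ccc(-c2cn(Cc3ccc(C(C)(C)C)cc3)nn2)c([N+](=O)[O-])c1`, carries nitro in place of amino on an aromatic carbon, ortho to a large group and meta to a methoxy group (nitro in place of amino on an aromatic carbon). For the measured compounds named here, no measured pair changes the amino group. Going by the values given here, the single measured step is large, an at least 12-fold lower number from compound 1 to compound 2 (1.09 log units; beyond the scatter), but it comes with hydrogen in place of methyl on an oxygen on an aromatic ring. Compound 3 keeps the methoxy group of compound 1, so the drop shown by an at least 12-fold lower number from compound 1 to compound 2 (1.09 log units; beyond the scatter) is not expected to carry over to it. From the compounds shown here alone, that step bears on the new change only indirectly, and the direction stays open. The expected outcome in this assay is no step beyond the scatter, with a step that the limit leaves unreadable from compound 1 to compound 3 as the estimated step. The estimate for compound 3 is 25000 nM, with an expected range from 8000 nM to 60000 nM.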

Compound 3, half-maximal inhibitory concentration: 1600 nM
Beside the measured number, compound 3's estimate is 16-fold (1.19 log units) above it; the whole stated range lies above it.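

In this assay, the position ortho to a large group proves able to move the read-out on its own: nitro in place of amino on an aromatic carbon gives an at least 12-fold lower number from compound 1 to compound 3 (1.09 log units; beyond the scatter). For the compounds shown here, the only step measured before this one lay at the methoxy group, so the amino position had no reading, and compound 3 now shows that the methoxy group alone does not hold a compound of this series at the limit. The true size of the new step stays unknown, since compound 1 is known only as a limit and not as a number: the limit of > 20000 nM in this assay, at which 1 of the 3 values shown sits.

The compounds shown do not separate the arrival of nitro from the loss of amino, and a plain hydrogen, a nitrile or a chlorine at the same place would be needed to tell these two apart. From the compounds shown here alone, it also stays open whether nitro in place of amino gives a step of similar size on the hydroxy compound 2, where the amino group sits on a core that already reads well inside the range of the assay.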